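The source may hold more compounds than are shown below. What is called first, only, known or untested is meant among the compounds shown, and "the series" means these compounds.

The compounds here share one core and differ at the far end of a chain. In an ADME assay on BJ cells (Homo sapiens) for cytotoxicity, with a stated time of 72 h (on this read-out higher numbers stand for an effect only at larger amounts of compound and lower numbers for an effect already at smaller amounts), compound 1 (`C=C[C@@](C)(/C=C/c1ccc(O)cc1)CCC(O)C(C)(C)O`) gives > 36600 nM as a limit of the assay, not a number. Compound 2 (`C=C[C@@](C)(/C=C/c1ccc(O)cc1)CCCO`) gives > 36600 nM as a limit too. Compound 3 (`C=C[C@@](C)(/C=C/c1ccc(O)cc1)CC/C=C/C(=O)OCC`) gives > 36600 nM and this is again a limit, so it has no number of its own. All the data so far amount to the limit of > 36600 nM in this assay, at which 3 of the 3 values shown sit, and nothing finer.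

Compound 4 (`C=C[C@@](C)(/C=C/c1ccc(O)cc1)CC/C=C/C(=O)c1ccccc1`) differs from compound 3 by one swap, phenyl in place of ethoxy on a carbonyl carbon, so that ethoxycarbonyl becomes benzoyl. For the measured compounds named here, two measured steps bear on this end of the chain (a step that the two limits leave unreadable from compound 1 to compound 3 and a step that the two limits leave unreadable from compound 2 to compound 3) and neither has a readable size. Neither of them makes this swap.

Going by the values given here, the only anchor is compound 3 with its limit of > 36600 nM and nothing more. A limit is therefore the likeliest report again for compound 4, and any real number would be expected to lie towards an effect at smaller amounts. The expected change is an at least 1.2-fold lower number from compound 3 to compound 4 (0.08 log units; that floor lies within the scatter) and it is a cautious estimate. For compound 4 the estimated value is 30000 nM with an expected range from 8000 nM to 80000 nM in this assay as the read-out.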

Compound 4, half-maximal effective concentration: > 36600 nM
Compound 4 was reported as a limit; the forecaster's own chance of this, stated with the estimate: 60%; middle value at least 1.2-fold (0.08 log units) away from the limit.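

Compound 3 and compound 4 both give a limit rather than a number, so the step with phenyl in place of ethoxy cannot be read. The whole series still rests on one result: the limit of > 36600 nM in this assay, at which 4 of the 4 values shown sit. The compounds shown leave open whether any change at the far end of the chain alters the value in this assay.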